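Swapping trifluoromethyl for chloro on the outer aryl urea

This account rests on a few compounds, and the source may have more. Where it says the series, first, only, none or still open, it means among the compounds named here.

Measured so far in a functional assay on MDA-MB-231 cells (Homo sapiens) for inhibition, read by MTT assay and WST assay, with a stated time of 72 h, tested at 10 uM; a lower number here means less inhibition of growth, a higher number more inhibition of growth at the concentration tested:
compound 1 `O=C(Nc1ccc(Cl)cc1)Nc1ccc(Oc2ccc(-c3nccs3)cc2)cc1`: 32.5%
compound 2 `O=C(Nc1ccc(Oc2ccc(-c3nccs3)cc2)cc1)Nc1ccc(Cl)c([N+](=O)[O-])c1`: 72.8%
compound 3 `O=C(Nc1ccc(Oc2ccc(-c3nccs3)cc2)cc1)Nc1ccc(F)c(C(F)(F)F)c1`: 71.8%

Compound 3 stands second highest of these three; its number and that of compound 2 lie within the scatter of each other, as the step of a number 1 percentage points lower from compound 2 to compound 3 (within the scatter) shows, while the step of a number 39.3 percentage points higher from compound 1 to compound 3 (beyond the scatter) is large. Compound 4 `O=C(Nc1ccc(Oc2ccc(-c3nccs3)cc2)cc1)Nc1ccc(F)c(Cl)c1` differs from compound 3 by chloro in place of trifluoromethyl on an aromatic carbon. Both steps that bear on this, a number 40.3 percentage points higher from compound 1 to compound 2 (beyond the scatter) and a number 39.3 percentage points higher from compound 1 to compound 3 (beyond the scatter), show that a second substituent on that phenyl ring went with a large rise, but the gap from compound 1 to compound 4 is smaller than either, so a moderate step is expected, not beyond the scatter in any sure direction: a number 14.8 percentage points lower from compound 3 to compound 4 (beyond the scatter). Compound 4 is estimated at 57%, in the range 35% to 78%.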

Compound 4, percent growth inhibition at one concentration: 43.9%
Beside the measured number, compound 4's estimate is 13.1 percentage points above it; measured number inside the range.
By their numbers in this assay, from the lowest: compound 1; then compound 4; then compounds 3 and 2 (each within the scatter of the next).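

In this assay, chloro does not stand in for trifluoromethyl at this place, ortho to a fluoro group, as shown by a number 27.9 percentage points lower from compound 3 to compound 4 (beyond the scatter). The 3-chloro-4-fluorophenyl group still keeps part of the gain over 4-chlorophenyl, with a number 11.4 percentage points higher from compound 1 to compound 4 (beyond the scatter), but it falls short of 4-chloro-3-nitrophenyl, with a number 28.9 percentage points lower from compound 2 to compound 4 (beyond the scatter). So among these compounds, the rise depends on which second substituent is present, not merely on there being one. Nothing measured here gives a reason for these steps. On these data alone, how an amine, a carboxylic acid or a methoxy group would fare at this place remains open.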